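This account rests on a few compounds, and the source may have more. Where it says the series, first, only, none or still open, it means among the compounds named here.

Measured compounds:
compound 1 `CCCCNc1nc(N)nc2cccc(OC)c12` — in an ADME assay on HEK293 cells for agonist activity at Toll-like receptor 8 (Homo sapiens), read by a luciferase reporter, with a stated time of 6 h (on this read-out higher numbers stand for an effect only at larger amounts of compound and lower numbers for an effect already at smaller amounts), compound 1 gives 0.1 uM.
compound 2 `CCCCNc1nc(N)nc2cccc(OCc3ccccc3OC)c12` — in this assay compound 2 gives only a limit of the assay, > 25 uM.

For the measured compounds named here, compound 1 holds the only number in this set; the other result is a limit (the limit of > 25 uM in this assay, at which 1 of the 2 values shown sits). Compound 3 `CCCCNc1nc(N)nc2cccc(C(=O)NC)c12` is the next member, carrying (methylcarbamoyl in place of methoxy on an aromatic carbon). Going by the values given here, the single measured step, an at least 250-fold higher number from compound 1 to compound 2 (2.39 log units; beyond the scatter), arose from a 2-methoxyphenyl in place of hydrogen on a saturated chain carbon bound to an oxygen on an aromatic ring, a different change from the one leading to compound 3, so it offers no direct precedent, only the sign that alterations of the methoxy can cost a great deal. For compound 3 a step in this assay, a 10-fold higher number from compound 1 to compound 3 (1.00 log units; beyond the scatter), toward higher numbers is therefore expected, though of uncertain size. Compound 3 is estimated at 1 uM, within 0.1 uM to 25 uM.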

Compound 3, minimum effective concentration: 0.39 uM
Compound 3: middle estimate off by 2.6-fold (0.41 log units), on the high side; the measured number falls inside the stated range.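

In this assay, methylcarbamoyl in place of methoxy on this aromatic carbon, ortho to a fused ring, gives a 3.9-fold higher number from compound 1 to compound 3 (0.59 log units; beyond the scatter). This step is modest but beyond the scatter, and it shows that the position can take a group with more heavy atoms and a hydrogen-bond donor while still giving a measured number, so change here need not end in a limit of the assay. Nothing measured in this set bears on why the step has this size.

Going by these compounds, whether the step follows from the amide hydrogen, the carbonyl or the added heavy atoms stays open, since this one change alters them together. A dimethylcarbamoyl group, a nitrile or a carboxylic acid on the same aromatic carbon would bear on that question.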